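The compounds below may be only part of what the source reports. "The series", "measured", "known", "first", "only" and "open" are said of these compounds alone.

Going by the values given here, compound 3 `COc1nc2ccc(Br)cc2cc1C(c1ccccc1)n1cc(CCO)nn1` is one of three compounds measured in an ADME assay on PC-3 cells (Homo sapiens) for cytotoxicity, read by sulforhodamine B assay, with a stated time of 48 h, tested at 10 uM; a higher number here means more inhibition at the concentration tested (going by the name of the read-out), a lower number less inhibition. In this assay compound 3 gives 15.5%, the second highest of the three numbers; compound 2 `COc1nc2ccc(Br)cc2cc1C(c1ccccc1)n1cc(-c2ccc(OC(F)(F)F)cc2)nn1` gives 21.6% and compound 1 `COc1nc2ccc(Br)cc2cc1C(c1ccccc1)n1cc(-c2ccccc2)nn1` gives 5.97%, both within the scatter of compound 3. Compound 4 `COc1nc2ccc(Br)cc2cc1C(c1ccccc1)n1cc(-c2cccc(F)c2)nn1` differs from compound 3 by 3-fluorophenyl in place of 2-hydroxyethyl on an aromatic carbon. Among the compounds with values here, two measured steps bear on this change: a number 9.5 percentage points higher from compound 1 to compound 3 (within the scatter) and a number 6.1 percentage points lower from compound 2 to compound 3 (within the scatter), both within the scatter. Within the data shown here, the only step beyond the scatter is a number 15.6 percentage points higher from compound 1 to compound 2 (beyond the scatter), a trifluoromethoxy in place of hydrogen, which compound 4 does not carry. A step within the scatter, in either direction, is therefore expected. Compound 4 is estimated at 12%, with a range from 0% to 26%. The expected step is a number 3.5 percentage points lower from compound 3 to compound 4 (within the scatter).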

Compound 4, a percentage reported as inhibition, at one concentration (the size of the read-out at that concentration, not a potency): 14.6%
Beside the measured number, compound 4's estimate is 2.6 percentage points below it, within the range that was stated.
By their numbers in this assay, from the lowest: compounds 1, 4, 3 and 2 (each within the scatter of the next, the first and the last beyond it).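

In this assay, 3-fluorophenyl in place of 2-hydroxyethyl gives a number 0.9 percentage points lower from compound 3 to compound 4 (within the scatter), so at this position the larger aromatic ring and the short alcohol chain cannot be told apart. The other two steps, a number 7 percentage points lower from compound 2 to compound 4 (within the scatter) and a number 8.6 percentage points higher from compound 1 to compound 4 (within the scatter), are also within the scatter, so neither exchanging 4-(trifluoromethoxy)phenyl for 3-fluorophenyl nor adding fluoro to the phenyl ring has a clear effect. No measurement here bears on a cause. As far as these compounds go, whether an amine or a carboxylic acid at this position would give a step beyond the scatter remains open.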